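Aryloxypropanoic acids: chloro to methyl on the benzyl ring

The source may hold more compounds than are shown below. What is called first, only, known or untested is meant among the compounds shown, and "the series" means these compounds.

Measured compounds:
compound 1 `CC(C)c1ccc(OC(Cc2ccc(Cl)cc2)C(=O)O)cc1` — 10 mg/kg
compound 2 `Cc1ccc(CC(Oc2ccc(C(C)C)cc2)C(=O)O)cc1` — < 50 mg/kg
compound 3 `CC(C)c1ccc(OC(C)(Cc2cccc(Cl)c2)C(=O)O)cc1` — 5 mg/kg

In a functional assay on the whole organism for inhibition, with Rattus norvegicus as the target (on this read-out higher numbers stand for an effect only at larger amounts of compound and lower numbers for an effect already at smaller amounts), compound 1 gives 10 mg/kg. For compound 2 the read-out is only a limit of the assay, < 50 mg/kg, and the limit of < 50 mg/kg in this assay, at which 1 of the 3 values shown sits, marks that this is one of the values shown. Compound 3 gives 5 mg/kg in this assay, which sits within the scatter of compound 1, so no order between the two is claimed. The difference between the cores of compound 1 and compound 3 is not broken down here.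

The change from compound 1 to compound 2 is methyl in place of chloro on an aromatic carbon. Its step, a step that the limit leaves unreadable from compound 1 to compound 2, cannot be read because compound 2 carries a limit.

Compound 4 `Cc1cccc(CC(C)(Oc2ccc(C(C)C)cc2)C(=O)O)c1` has not yet been measured in this assay. It differs from compound 3 by methyl in place of chloro on an aromatic carbon; this is the same kind of change as from compound 1 to compound 2, but the place differs: there para to a large group, here meta to a large group. No readable step of this kind exists among the measured compounds, so the expectation rests only on the value of compound 3, 5 mg/kg, and the unreadable step from compound 1 to compound 2. Compound 4 is expected to give about 8 mg/kg in this assay, between 3 mg/kg and 25 mg/kg, which means an estimated step of a 1.6-fold higher number from compound 3 to compound 4 (0.20 log units; within the scatter).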

Compound 4, dose for half-maximal effect: < 1 mg/kg
Compound 4 was reported as a limit; the forecaster's own chance of this, stated with the estimate: 20%; middle value at least 8.0-fold (0.90 log units) away from the limit.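

On the core of compound 3, methyl in place of chloro gives in this assay an at least 5.0-fold lower number from compound 3 to compound 4 (0.69 log units; beyond the scatter), a step beyond the scatter. Compound 4 carries a limit, so this step is open-ended on one side: the limit of < 1 mg/kg in this assay, at which 1 of the 4 values shown sits. Whether the change carries from one core to another is not shown, since the only readable step lies on the core of compound 3 and the step on the core of compound 1 cannot be read, compound 2 carrying a limit: the limit of < 50 mg/kg in this assay, at which 1 of the 4 values shown sits.

For the compounds shown here, open is how far the step belongs to methyl itself, as the core of compound 3 shows only the pair 3-chlorophenyl and 3-methylphenyl, and an ethyl, a methoxy or an amine at the same place would test this. Also open, on these data alone, is whether the same change on further cores of the series follows compound 4 or gives no step beyond the scatter.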